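Changing the aryl amide ring: bromo to hydroxy

This account rests on a few compounds, and the source may have more. Where it says the series, first, only, none or still open, it means among the compounds named here.

- compound 1 `CN(C)C(=O)c1cc2cnc(Nc3ccc(NC(=O)C4(C(=O)Nc5ccc(Br)cc5)CC4)cc3)nc2n1C1CCCC1` gives 94.3%
- compound 2 `CN(C)C(=O)c1cc2cnc(Nc3ccc(NC(=O)C4(C(=O)Nc5cccc(C(F)(F)F)c5)CC4)cc3)nc2n1C1CCCC1` gives 92.7%
- compound 3 `CN(C)C(=O)c1cc2cnc(Nc3ccc(NC(=O)C4(C(=O)Nc5cccc(Br)c5)CC4)cc3)nc2n1C1CCCC1` gives 94.6%

In a functional assay on T47D cells (Homo sapiens) for inhibition, read by CCK-8 assay, with a stated time of 72 h, tested at 10 uM (a lower number here means less inhibition of growth, a higher number more inhibition of growth at the concentration tested), compound 3, at 94.6%, cannot be told apart from the other two compounds, since all the steps among them stay within the scatter. Compound 4 `CN(C)C(=O)c1cc2cnc(Nc3ccc(NC(=O)C4(C(=O)Nc5ccc(O)cc5)CC4)cc3)nc2n1C1CCCC1` carries 4-hydroxyphenyl in place of 3-bromophenyl on an amide-type nitrogen.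

The measured steps bearing on this change alter the same aryl group, and all are small: a number 0.3 percentage points higher from compound 1 to compound 3 (within the scatter), a number 1.6 percentage points lower from compound 1 to compound 2 (within the scatter) and a number 1.9 percentage points higher from compound 2 to compound 3 (within the scatter). Going by the values given here, they exchange only bromo and trifluoromethyl groups, however, and no measured compound carries a hydroxy group, so they guide this step only weakly. A fall in this assay is therefore expected, cautiously and with an uncertain size. The estimated step is a number 12.6 percentage points lower from compound 3 to compound 4 (beyond the scatter). For compound 4 the expected value is 82%, with an estimated range from 55% to 96%.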

Compound 4, percent growth inhibition at one concentration: 95.8%
Beside the measured number, compound 4's estimate is 13.8 percentage points below it; the measured number falls inside the stated range.
By their numbers in this assay, from the lowest: compounds 2, 1, 3 and 4 (each within the scatter of the next).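

In this assay, placing 4-hydroxyphenyl on the amide-type nitrogen leaves the result indistinguishable from the bromo and trifluoromethyl rings: a number 1.2 percentage points higher from compound 3 to compound 4 (within the scatter), a number 3.1 percentage points higher from compound 2 to compound 4 (within the scatter) and a number 1.5 percentage points higher from compound 1 to compound 4 (within the scatter). This position therefore tolerates a ring bearing a hydrogen-bond donor and acceptor as well as the 3-bromophenyl ring, which has neither, so the change is not penalised at the single concentration tested. Nothing available here explains this tolerance.

As far as these compounds go, all four compounds give high numbers at that one concentration, so it remains open whether they would separate at lower concentrations. From the compounds shown here alone, it is also open whether an amine or a carboxylic acid in place of the hydroxy group would give a similar result.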